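The source may report more compounds than this note shows. Statements on the series, on what has been measured and on what is new or still open speak of the compounds shown alone.

Series notes. Compound 2 `CCN(CC)Cc1ccc2nc(NC(=O)N/N=C/c3cn(Cc4cccc(Cl)c4)c4ccccc34)sc2c1` and compound 1 `CC1CCN(Cc2ccc3nc(NC(=O)N/N=C/c4cn(Cc5cccc(Cl)c5)c5ccccc45)sc3c2)CC1` share one core; compound 3 `CCN(CC)Cc1ccc2nc(NC(=O)N/N=C/c3cn(Cc4ccccc4)c4ccccc34)sc2c1` has the core of compound 2 changed by hydrogen in place of chloro on an aromatic carbon, which in this assay gave a 1.4-fold lower number from compound 2 to compound 3 (0.14 log units; within the scatter). Compound 4 `CC1CCN(Cc2ccc3nc(NC(=O)N/N=C/c4cn(Cc5ccccc5)c5ccccc45)sc3c2)CC1` is not yet measured. In a functional assay on MDA-MB-231 cells (Homo sapiens) for cytotoxicity, read by MTT assay, with a stated time of 72 h (on this read-out lower numbers stand for stronger inhibition and higher numbers for weaker inhibition), compound 1 gives 2110 nM, compound 2 gives 2050 nM, and compound 3 gives 1470 nM. The change 4-methylpiperidin-1-yl in place of diethylamino on a saturated chain carbon bound to an aromatic carbon made the step of a 1.0-fold higher number from compound 2 to compound 1 (0.01 log units; within the scatter). Compound 4 differs from compound 3 by 4-methylpiperidin-1-yl in place of diethylamino on a saturated chain carbon bound to an aromatic carbon, the same change, at the same place, so two instances of it exist among these compounds. From compound 3 to compound 4 the expected step is a 1.0-fold higher number from compound 3 to compound 4 (0.01 log units; within the scatter), resting on compound 2 and compound 1 with a 1.0-fold higher number from compound 2 to compound 1 (0.01 log units; within the scatter) and on compound 3 at 1470 nM. The estimate for compound 4 in this assay is 1500 nM, expected between 850 nM and 2700 nM.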

Compound 4, half-maximal inhibitory concentration: 2850 nM
Compound 4: the middle estimate sits 1.9-fold (0.28 log units) below what was measured; the whole stated range lies below it.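

In this assay, 4-methylpiperidin-1-yl in place of diethylamino on a saturated chain carbon bound to an aromatic carbon gave a 1.9-fold higher number from compound 3 to compound 4 (0.29 log units; within the scatter), and this step cannot be told apart from the earlier one: the same change on two cores in this assay, a 1.0-fold higher number (0.01 log units; within the scatter) from compound 2 to compound 1 and a 1.9-fold higher number (0.29 log units; within the scatter) from compound 3 to compound 4, 1.9-fold (0.27 log units) apart, within the scatter of two such steps

Hydrogen in place of chloro on an aromatic carbon gave a 1.4-fold higher number from compound 1 to compound 4 (0.13 log units; within the scatter), and it also cannot be told apart from its earlier counterpart: the same change on two cores in this assay, a 1.4-fold lower number (0.14 log units; within the scatter) from compound 2 to compound 3 and a 1.4-fold higher number (0.13 log units; within the scatter) from compound 1 to compound 4, 1.9-fold (0.27 log units) apart, within the scatter of two such steps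

Across these four compounds, neither change shows a dependence on the core, but with every step within the scatter, this does not show that the steps are equal or that either change has an effect of its own.

On these data alone, whether morpholin-4-yl or piperazin-1-yl in place of diethylamino would give a step beyond the scatter remains open. The same holds for fluoro or methoxy in place of chloro on an aromatic carbon.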